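Swapping Phenyl for Iodo on a Fused Core

The compounds below may be only part of what the source reports. "The series", "measured", "known", "first", "only" and "open" are said of these compounds alone.

Compound 1 `Cc1cc(-c2ccccc2)c2ncc(CSCCc3ccccc3)n2c1` was tested in an ADME assay on HEL cells (Homo sapiens) for cytotoxicity, with a stated time of 3 days (on this read-out lower numbers stand for higher toxicity in this test and higher numbers for lower toxicity in this test), where compound 1 gives 20 ug/mL. Compound 2 `Cc1cc(-c2ccccc2)cn2c(CSCCc3ccccc3)cnc12`, built from the same groups on a related core, gives 20 ug/mL in this assay, so compound 1 stands level with compound 2, within the scatter. Compound 3 `Cc1cc(I)c2ncc(CSCCc3ccccc3)n2c1` has not been measured yet; it differs from compound 1 in one place: iodo in place of phenyl on an aromatic carbon. Phenyl leaves and iodo enters on the fused core. Going by the values given here, with no measured step of this kind to lean on, the step of no change at the digits printed from compound 1 to compound 3 (within the scatter) is expected to stay within the scatter. Compound 3 is therefore estimated at 20 ug/mL, with a range from 7 ug/mL to 60 ug/mL.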

Compound 3, minimum cytotoxic concentration: >= 4 ug/mL
Compound 3 ended at the assay's limit; the forecaster's own chance of this, stated with the estimate: 15%; the middle value lies beyond the limit too.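

The size of the change from compound 1 to compound 3 cannot be read, because compound 3 gives a limit of the assay and not a number: the limit of >= 4 ug/mL in this assay, at which 1 of the 3 values shown sits. The compounds shown leave open how iodo in place of phenyl alters toxicity to these cells.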